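This account rests on a few compounds, and the source may have more. Where it says the series, first, only, none or still open, it means among the compounds named here.

- Compound 1 `O=C1CC(c2cnc(C(F)(F)F)s2)CN1c1cnn2c1CN(C(=O)Nc1cc(F)c(F)c(F)c1)C(C1CC1)C2`: 38500 nM
- Compound 2 `O=C1CC(c2ccc(F)cn2)CN1c1cnn2c1CN(C(=O)Nc1cc(F)c(F)c(F)c1)C(C1CC1)C2`: 38500 nM

In a toxicity assay on HepG2 2.2.15 cells (Homo sapiens) for cytotoxicity, read by CellTiter-Glo (a lower number here means that less compound is tolerated, a higher number that more compound is tolerated), compound 2 gives 38500 nM, level with compound 1 at 38500 nM. Compound 3 `O=C1CC(c2ccccn2)CN1c1cnn2c1CN(C(=O)Nc1cc(F)c(F)c(F)c1)C(C1CC1)C2` differs from compound 2 by hydrogen in place of fluoro on an aromatic carbon, so that 5-fluoropyridin-2-yl becomes pyridin-2-yl. For the measured compounds named here, the one measured step that bears on this, no change at the digits printed from compound 1 to compound 2 (within the scatter), exchanged a whole group on a saturated ring carbon. The present edit is smaller, so no step beyond the scatter is expected in this assay. The expected change is no change at the digits printed from compound 2 to compound 3 (within the scatter). The estimate for compound 3 is 38500 nM, within an expected range of 24000 nM to 60000 nM.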

Compound 3, half-maximal cytotoxic concentration: 96200 nM
Estimate against measurement, compound 3: 2.5-fold (0.40 log units) below; measured number above the stated range.
By their numbers in this assay, from the lowest: compounds 1 and 2 (each within the scatter of the next); then compound 3.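

In this assay, putting hydrogen in place of fluoro gives a 2.5-fold higher number from compound 2 to compound 3 (0.40 log units; beyond the scatter), so a single atom on this ring shifts the number, where the earlier exchange of a whole group did not. The pyridin-2-yl group also separates from 2-(trifluoromethyl)-1,3-thiazol-5-yl, with a 2.5-fold higher number from compound 1 to compound 3 (0.40 log units; beyond the scatter). Nothing measured here explains this shift. Open, from the compounds shown here alone, is whether the higher number belongs to hydrogen alone, or whether chloro, methyl or methoxy on the same aromatic carbon would give it too.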